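Thiazolyl on the sulfonamide nitrogen of a chlorocoumarin imine

A few compounds are considered here, and "the series" means these few. Any claim that something is new, unique, unknown or untested is made for them only; others in the source may bear on it.

Three compounds sharing a chlorinated coumarin linked through an imine to a benzenesulfonamide have been tested in a functional assay on B16-F10 cells (Mus musculus) for cytotoxicity, read by CCK-8 assay, with a stated time of 48 h; a higher number here means a weaker inhibitor, a lower number a stronger inhibitor. Compound 1 `N=C(N)NS(=O)(=O)c1ccc(/N=C/c2c(Cl)c3ccccc3oc2=O)cc1` gives 180 nM. Compound 2 `Cc1cc(C)nc(NS(=O)(=O)c2ccc(/N=C/c3c(Cl)c4ccccc4oc3=O)cc2)n1` gives 170 nM, and the exchange of groups on the sulfonamide nitrogen between them, a 1.1-fold lower number from compound 1 to compound 2 (0.02 log units; within the scatter), leaves the number essentially unchanged. Compound 3 `CC(C)(C)c1cc(C(C)(C)C)c2oc(=O)c(/C=N/c3ccc(S(N)(=O)=O)cc3)c(Cl)c2c1`, which carries two tert-butyl groups on the coumarin and a bare sulfonamide, gives 240 nM. That is the highest of the three numbers, but its gaps to compound 1 and to compound 2 both lie within the scatter, so the three cannot be told apart.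

Compound 4 `CC(C)(C)c1cc(C(C)(C)C)c2oc(=O)c(/C=N/c3ccc(S(=O)(=O)Nc4nccs4)cc3)c(Cl)c2c1` is the unmeasured partner of compound 3. The change is 1,3-thiazol-2-yl in place of hydrogen on a sulfonamide nitrogen. Among the measured compounds shown here, the only measured step at this place, the one from compound 1 to compound 2, swaps one nitrogen substituent for another and stays within the scatter; compounds 1 and 2 also show that a substituted sulfonamide nitrogen on the unsubstituted coumarin core gives numbers close to the bare sulfonamide of compound 3. Nothing measured points to a shift in this assay. The expected step is a 1.1-fold lower number from compound 3 to compound 4 (0.04 log units; within the scatter), that is, no change beyond the scatter. Compound 4 is therefore estimated at 220 nM, within 100 nM to 480 nM.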

Compound 4, half-maximal inhibitory concentration: 160 nM
The estimate for compound 4 lay 1.4-fold (0.14 log units) above the measured number; the measured number falls inside the stated range.
By their numbers in this assay, from the lowest: compounds 4, 2, 1 and 3 (each within the scatter of the next).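

Among the compounds shown here, this is the first direct reading of what a ring does in place of hydrogen on the sulfonamide nitrogen with the rest of the molecule held fixed, since compounds 1 and 2 only exchange one substituent for another, and compound 3 differs from both in more than one place. In this assay, the step of a 1.5-fold lower number from compound 3 to compound 4 (0.18 log units; within the scatter) shows that adding 1,3-thiazol-2-yl, a five-membered aromatic ring, to the bare sulfonamide of this tert-butyl-bearing molecule does not move the number beyond the usual scatter of repeated measurements. Nothing available here gives a measured property or other evidence that could explain this outcome.

Still open, from the compounds shown here alone, is whether a smaller or different group on this nitrogen, such as methyl, acetyl or a longer alkyl chain ending in an amine or a carboxylic acid, would shift the number beyond the scatter. Going by these compounds, it is also open whether 1,3-thiazol-2-yl would give a similar result on the core of compound 1, which carries no tert-butyl groups.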